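The source may hold more compounds than are shown below. What is called first, only, known or untested is meant among the compounds shown, and "the series" means these compounds.

Compound 2 `COc1ncnc2c1c(-c1ccoc1)cn2[C@@H]1O[C@H](CO)[C@@H](O)[C@H]1O` carries a furan-3-yl group on a shared core that also appears in compound 1 `COc1ncnc2c1c(-c1ccsc1)cn2[C@@H]1O[C@H](CO)[C@@H](O)[C@H]1O` and compound 3 `COc1ncnc2c1c(-c1ccccc1)cn2[C@@H]1O[C@H](CO)[C@@H](O)[C@H]1O`. In a functional assay on HepG2 cells (Homo sapiens) for antiproliferative activity, read by XTT assay, with a stated time of 72 h (on this read-out lower numbers stand for stronger inhibition and higher numbers for weaker inhibition), compound 2 gives 290 nM, and compound 1 gives 430 nM, so that a 1.5-fold lower number from compound 1 to compound 2 (0.17 log units; within the scatter). Compound 3 reaches only a limit of this assay, > 20000 nM, which is the limit of > 20000 nM in this assay, at which 1 of the 3 values shown sits. Against that limit, an at least 46-fold higher number from compound 1 to compound 3 (1.66 log units; beyond the scatter) and an at least 68-fold higher number from compound 2 to compound 3 (1.83 log units; beyond the scatter). Among the two plain numbers, compound 2 holds the lower one, with compound 1 nearest and within the scatter of it.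

Compound 4 `CNc1ncnc2c1c(-c1ccoc1)cn2[C@@H]1O[C@H](CO)[C@@H](O)[C@H]1O` differs from compound 2 by methylamino in place of methoxy on an aromatic carbon. Going by the values given here, none of the measured steps touches this group: all three exchange the aryl ring on the core, so they offer no direct guide to the size or direction of this change. Given that silence, the step is expected to stay within or only modestly beyond the scatter, with a 1.2-fold lower number from compound 2 to compound 4 (0.06 log units; within the scatter). Compound 4 is therefore estimated at 250 nM in this assay, within a range from 60 nM to 1200 nM.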

Compound 4, half-maximal inhibitory concentration: > 20000 nM
Compound 4 was reported as a limit; the forecaster's own chance of this, stated with the estimate: 5%; at least 80-fold (1.90 log units) between middle value and limit.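

Methylamino in place of methoxy on the aromatic carbon next to the ring nitrogen gives an at least 68-fold higher number from compound 2 to compound 4 (1.83 log units; beyond the scatter). Going by these compounds alone, until now only the aryl ring had been varied, so this is the first sign that the group at this second place on the shared core can also take the read-out out of range, even though the exchange keeps the heavy-atom count and adds one hydrogen-bond donor. Compound 4 gives a limit and not a number in this assay, so the full size of the step stays unknown: the limit of > 20000 nM in this assay, at which 2 of the 4 values shown sit.

The compounds shown do not tell whether an unsubstituted amine, a dimethylamino group or an ethoxy group at this carbon would behave like methoxy or like methylamino. From the compounds shown here alone, it also stays open whether methylamino has the same outcome with thiophen-3-yl on the core.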